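Trading a Methoxy for a Fluoro on the Aryl Arm

The source may report more compounds than this note shows. Statements on the series, on what has been measured and on what is new or still open speak of the compounds shown alone.

Measured in a functional assay on CCRF-CEM cells (Homo sapiens) for antiproliferative activity, read by resazurin assay, with a stated time of 72 h; on this read-out lower numbers stand for stronger inhibition and higher numbers for weaker inhibition:
compound 1 `N#Cc1c(-c2ccco2)nc2c(c(-c3ccccc3)nn2-c2ccccc2)c1-c1ccc(O)cc1` gives 23900 nM
compound 2 `COc1ccc(-c2nc3c(c(-c4ccccc4)nn3-c3ccccc3)c(-c3ccc(O)cc3)c2C#N)cc1` gives 6700 nM

Compound 2 holds the lowest of the two numbers; compound 1 sits above it by a 3.6-fold lower number from compound 1 to compound 2 (0.55 log units; beyond the scatter). Compound 3 `N#Cc1c(-c2ccc(F)cc2)nc2c(c(-c3ccccc3)nn2-c2ccccc2)c1-c1ccc(O)cc1` differs from compound 2 by fluoro in place of methoxy on an aromatic carbon. Among the measured compounds shown here, no measured step swaps these two groups; the only known step, a 3.6-fold lower number from compound 1 to compound 2 (0.55 log units; beyond the scatter), concerns a different replacement on that aromatic carbon and bears only loosely here. Compound 3 is therefore expected to stay close to compound 2, with a step of a 1.5-fold higher number from compound 2 to compound 3 (0.17 log units; within the scatter) in this assay that need not exceed the scatter. Compound 3 is estimated at 10000 nM, within 3000 nM to 35000 nM.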

Compound 3, half-maximal inhibitory concentration: > 25000 nM
Compound 3 was reported as a limit; the forecaster's own chance of this, stated with the estimate: 5%; middle value at least 2.5-fold (0.39 log units) from the limit.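

In this assay compound 3 is reported only as a limit: the limit of > 25000 nM in this assay, at which 1 of the 3 values shown sits. At this aromatic carbon, the lower number seen with 4-methoxyphenyl does not carry over to 4-fluorophenyl (an at least 3.7-fold higher number from compound 2 to compound 3 (0.57 log units; beyond the scatter)). Against furan-2-yl the floor is only (an at least 1.0-fold higher number from compound 1 to compound 3 (0.01 log units; that floor lies within the scatter)), so the limit does not tell whether the 4-fluorophenyl arm differs from furan-2-yl at all.

From the compounds shown here alone, the actual value of compound 3 remains open. So does whether an amine or a longer ether chain such as ethoxy in place of the methoxy would keep the number of compound 2.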